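The compounds below may be only part of what the source reports. "The series", "measured", "known", "first", "only" and "open" are said of these compounds alone.

In a functional assay on MDA-MB-231 cells (Homo sapiens) for antiproliferative activity, read by MTT assay, with a stated time of 72 h (on this read-out lower numbers stand for stronger inhibition and higher numbers for weaker inhibition), compound 2 `NC1=NC2(CCOCC2)N(OCCCOc2ccccc2)C(N)=N1` has no number to stand on, since its result is "not determined" (no result reported). Compound 4 `NC1=NC2(CCOCC2)N(OCCCOc2cccc(Cl)c2Cl)C(N)=N1` shares the core of compound 2 and differs from it in one place: 2,3-dichlorophenyl in place of phenyl on an oxygen on a saturated carbon, with 2,3-dichlorophenyl in place of phenyl on an oxygen on a saturated carbon. The nearest evidence comes from another core, where compound 1 `NC1=NC2(CCSCC2)N(OCCCOc2ccc(Cl)c(Cl)c2)C(N)=N1` gives 10 nM and compound 3 `NC1=NC2(CCSCC2)N(OCCCOc2ccc(Br)cc2)C(N)=N1` gives 440 nM. That single measured step, a 44-fold higher number from compound 1 to compound 3 (1.64 log units; beyond the scatter), is large, but it swaps one substituted aryl group for another and does not start from phenyl. With no value for compound 2, no size or direction of step can be expected in this assay, so only an absolute estimate is possible, bracketed loosely by those two values. Compound 4 is expected near 100 nM, with an estimated range from 15 nM to 700 nM.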

Compound 4, half-maximal inhibitory concentration: 140 nM
Estimate against measurement, compound 4: 1.4-fold (0.15 log units) below; low and high end bracket the measured number.
By their numbers in this assay, from the lowest: compound 1; then compound 4; then compound 3.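

No step can be read between compound 2 and compound 4. The compounds shown leave open what 2,3-dichlorophenyl in place of phenyl does to activity on this core. No evidence on hand bears on the result.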